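This account rests on a few compounds, and the source may have more. Where it says the series, first, only, none or still open, it means among the compounds named here.

In a functional assay on MCF7 cells (Homo sapiens) for antiproliferative activity, read by MTT assay, with a stated time of 48 h (a higher number here means a weaker inhibitor, a lower number a stronger inhibitor), compound 1 `O=C(NS(=O)(=O)c1ccccc1)c1cncc(Br)c1` gives 12900 nM and compound 2 `Cc1ccc(S(=O)(=O)NC(=O)c2cncc(Br)c2)cc1` gives 9370 nM. Among the measured compounds shown here, compound 1 therefore stands level with the only other measured compound, as the two values lie within the scatter. Compound 3 `O=C(NS(=O)(=O)c1ccc(Br)cc1)c1cncc(Br)c1` keeps the core of compound 1 and differs from it in one place: bromo in place of hydrogen on an aromatic carbon. Put simply, this is bromo in place of hydrogen on an aromatic carbon, para to a large group.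

For the measured compounds named here, only one measured step bears on this change, the similar swap of methyl in place of hydrogen on an aromatic carbon, which gave a 1.4-fold lower number from compound 1 to compound 2 (0.14 log units; within the scatter). With a single small step as the guide, and with bromo not being methyl, no step beyond the scatter is expected in this assay, though a slightly lower number seems likelier than a higher one. The expected step is a 1.4-fold lower number from compound 1 to compound 3 (0.16 log units; within the scatter). For compound 3 the estimated value is 9000 nM, with an expected range of 4000 nM to 18000 nM.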

Compound 3, half-maximal inhibitory concentration: 340 nM
Compound 3: the middle estimate sits 26-fold (1.42 log units) above what was measured, outside the stated range (below it).
By their numbers in this assay, from the lowest: compound 3; then compounds 2 and 1 (each within the scatter of the next).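

In this assay, the aromatic carbon para to a large group proves far more sensitive than the methyl compound suggested: bromo in place of hydrogen gives a 38-fold lower number from compound 1 to compound 3 (1.58 log units; beyond the scatter) while methyl in place of hydrogen gave only a 1.4-fold lower number from compound 1 to compound 2 (0.14 log units; within the scatter) and stayed within the scatter. Putting bromo in place of methyl at the same carbon gives a 28-fold lower number from compound 2 to compound 3 (1.44 log units; beyond the scatter) so among these compounds, the large drop in the number comes with bromo and not with methyl. Nothing available explains why these two groups differ so sharply at this carbon.

On these data alone, it remains open whether the drop is particular to bromo or would also appear with chloro, fluoro, methoxy or an amine at this carbon. The bromo shared by all three compounds also stays unchanged, so its part in these values cannot be judged.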